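Antiproliferative series: one substitution made on two cores

The source may hold more compounds than are shown below. What is called first, only, known or untested is meant among the compounds shown, and "the series" means these compounds.

Measured so far:
Compound 1 `C=CCOc1ncnc2c1ncn2C1COc2ccccc2CO1`: 5040 nM
Compound 2 `c1ccc(Sc2ncnc3c2ncn3C2COc3ccccc3CO2)cc1`: 7120 nM
Compound 3 `C=CCOc1ncnc2ncn(C3COc4ccccc4CO3)c12`: 20900 nM

All three values come from a functional assay on MCF7 cells (Homo sapiens) for antiproliferative activity, read by sulforhodamine B assay, with a stated time of 3 days; on this read-out lower numbers stand for stronger inhibition and higher numbers for weaker inhibition. Compound 1 and compound 2 differ only by phenylsulfanyl in place of allyloxy on an aromatic carbon, and the step is a 1.4-fold higher number from compound 1 to compound 2 (0.15 log units; within the scatter). Compound 3 has the same atoms as compound 1 joined differently; the difference between the two cores is not broken down here. In this assay compound 3 gives the highest of the three numbers, beyond the scatter from compound 2 and from compound 1.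

Compound 4 `c1ccc(Sc2ncnc3ncn(C4COc5ccccc5CO4)c23)cc1` is not yet measured. It differs from compound 3 by phenylsulfanyl in place of allyloxy on an aromatic carbon, the same change as between compound 1 and compound 2. The expected step is a 1.4-fold higher number from compound 3 to compound 4 (0.14 log units; within the scatter). This expectation rests on the step of a 1.4-fold higher number from compound 1 to compound 2 (0.15 log units; within the scatter). Compound 4 is estimated at 29000 nM, between 12000 nM and 70000 nM.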

Compound 4, half-maximal inhibitory concentration: 15600 nM
Compound 4: middle estimate off by 1.9-fold (0.27 log units), on the high side; low and high end bracket the measured number.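

In this assay, phenylsulfanyl in place of allyloxy on an aromatic carbon gives a 1.3-fold lower number from compound 3 to compound 4 (0.13 log units; within the scatter). Set beside the earlier step, the change shows no difference between the two cores: the same change on two cores in this assay, a 1.4-fold higher number (0.15 log units; within the scatter) from compound 1 to compound 2 and a 1.3-fold lower number (0.13 log units; within the scatter) from compound 3 to compound 4, 1.9-fold (0.28 log units) apart, within the scatter of two such steps. This shows that the swap between these two groups leaves the number within the scatter on both cores, but with neither step beyond the scatter it does not show that a change with a clear effect would carry from one core to the other.

Still open, on these data alone, is whether the two cores would track each other for a substitution that moves the number beyond the scatter. An amine, a carboxylic acid or a longer chain on that aromatic carbon would test this.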